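This account rests on a few compounds, and the source may have more. Where it says the series, first, only, none or still open, it means among the compounds named here.

Measured so far:
- compound 1, `Cc1nn(C)c(Oc2ccc(I)cc2)c1/C=N\CCCCCOc1cc2oc(=O)cc(C)c2cc1Cl`: > 25000 nM
- compound 2, `Cc1nn(C)c(Oc2cccc(F)c2)c1/C=N\CCCCCCOc1cc2oc(=O)cc(C)c2cc1Cl`: 23600 nM

Two compounds of the series have been run in a functional assay on SMMC-7721 cells (Homo sapiens) for antiproliferative activity, read by MTT assay, with a stated time of 72 h; on this read-out lower numbers stand for stronger inhibition and higher numbers for weaker inhibition. Compound 1, `Cc1nn(C)c(Oc2ccc(I)cc2)c1/C=N\CCCCCOc1cc2oc(=O)cc(C)c2cc1Cl`, returns only a limit of the assay, > 25000 nM, so no number stands for it. Within the data shown here, compound 2, `Cc1nn(C)c(Oc2cccc(F)c2)c1/C=N\CCCCCCOc1cc2oc(=O)cc(C)c2cc1Cl`, gives 23600 nM in this assay, and it is the only actual number in the set. This leaves compound 2 without a measured neighbour against which its value could be read as a step; the other result in the set is a limit, (the limit of > 25000 nM in this assay, at which 1 of the 2 values shown sits).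

Compound 3, `Cc1nn(C)c(Oc2cccc(Cl)c2)c1/C=N\CCCCCCOc1cc2oc(=O)cc(C)c2cc1Cl`, is the next member to be measured in this assay. It differs from compound 2 by one point: chloro in place of fluoro on an aromatic carbon. Among the measured compounds shown here, with no measured step in the set to lean on, the expectation is that this exchange moves the value by no more than the usual scatter, with no preferred direction. For compound 3 the step from compound 2 is estimated as a 1.2-fold lower number from compound 2 to compound 3 (0.07 log units; within the scatter). Compound 3 is therefore expected to land at about 20000 nM, with a range from 7000 nM to 50000 nM, and a real chance that, like compound 1, only a limit is reported.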

Compound 3, half-maximal inhibitory concentration: 5260 nM
Compound 3: the middle estimate sits 3.8-fold (0.58 log units) above what was measured, outside the stated range (below it).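

In this assay, 3-fluorophenoxy to 3-chlorophenoxy gives a 4.5-fold lower number from compound 2 to compound 3 (0.65 log units; beyond the scatter). Among these compounds, this is the first readable step, and it shows that this aromatic carbon, meta to a large group, is not silent: one halogen exchanged for another, with no change in rings, hydrogen-bond donors, hydrogen-bond acceptors or net charge, is enough to move the value beyond the scatter. Among the compounds shown here, compound 1 stays a limit of the assay, so no step to it can be read: the limit of > 25000 nM in this assay, at which 1 of the 3 values shown sits.

As far as these compounds go, a single step fixes no trend, and the data do not show what lies behind it, so whether a bromo or a methoxy group on the same aromatic carbon would extend the gain or lose it remains open. Also open, from the compounds shown here alone, is whether chloro in place of fluoro gives a step of similar size on a longer chain, or with an amine in place of the imine link of the shared core.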